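A few compounds are considered here, and "the series" means these few. Any claim that something is new, unique, unknown or untested is made for them only; others in the source may bear on it.

Measured so far in a functional assay on MCF7 cells (Homo sapiens) for inhibition, read by sulforhodamine B assay, with a stated time of 72 h; on this read-out higher numbers stand for weaker inhibition and lower numbers for stronger inhibition:
compound 1 `COc1ccc(C(=O)/C=C/c2cn(-c3ccccc3)nc2-c2cccnc2)cc1OC`: 1700 nM
compound 2 `O=C(/C=C/c1cn(-c2ccccc2)nc1-c1ccncc1)c1ccccc1`: 3400 nM
compound 3 `COc1cc(C(=O)/C=C/c2cn(-c3ccccc3)nc2-c2ccncc2)cc(OC)c1OC`: 3500 nM

Compound 3 carries the highest of the three numbers, but its gap to compound 2 lies within the usual scatter of this assay, so the two cannot be told apart; only compound 1 stands clearly lower, beyond the scatter. Compound 1 differs from compound 3 in two places at once, so its lower number cannot be tied to either change alone.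

Compound 4 `COc1ccc(C(=O)/C=C/c2cn(-c3ccccc3)nc2-c2ccncc2)cc1OC` is not yet measured. It comes from compound 3 by hydrogen in place of methoxy on an aromatic carbon, a hydrogen in place of methoxy on an aromatic carbon, on a six-membered aromatic ring of carbon only, ortho to a methoxy group and meta to a large group and to a methoxy group. Among the measured compounds shown here, no step between measured compounds in this assay matches this change, so there is no direct guide. The expected outcome for compound 4 is a small step, a 1.4-fold lower number from compound 3 to compound 4 (0.15 log units; within the scatter), toward a lower number, not clearly beyond the scatter. Compound 4 is estimated at 2500 nM, with a range from 1000 nM to 6000 nM.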

Compound 4, half-maximal inhibitory concentration: 4300 nM
Estimate against measurement, compound 4: 1.7-fold (0.24 log units) below; the measured number falls inside the stated range.
By their numbers in this assay, from the lowest: compounds 1, 2, 3 and 4 (each within the scatter of the next, the first and the last beyond it).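

In this assay, hydrogen in place of methoxy on this aromatic carbon gives a 1.2-fold higher number from compound 3 to compound 4 (0.09 log units; within the scatter), so with pyridin-4-yl in the core this methoxy, ortho to a methoxy group, can be lost without a readable shift. The swap from phenyl to 3,4-dimethoxyphenyl on the carbonyl carbon reads the same way, with a 1.3-fold higher number from compound 2 to compound 4 (0.10 log units; within the scatter) on the same core. Pyridin-4-yl in place of pyridin-3-yl gives a 2.5-fold higher number from compound 1 to compound 4 (0.40 log units; beyond the scatter), the only one of these single changes beyond the scatter, which ties the lower number of compound 1 to the pyridine attachment rather than to the aryl ketone.

Open, from the compounds shown here alone, is whether an amine or a carboxylic acid at this ring position would move the number at all, and whether pyridin-2-yl would follow pyridin-3-yl or pyridin-4-yl. No measurement at hand accounts for the pyridine step.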